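A few compounds are considered here, and "the series" means these few. Any claim that something is new, unique, unknown or untested is made for them only; others in the source may bear on it.

Among the compounds with values here, in a functional assay on SF-295 cells (Homo sapiens) (on this read-out higher numbers stand for weaker inhibition of growth and lower numbers for stronger inhibition of growth), compound 2 `COc1ccccc1-c1cc(O)c2cccnc2n1` gives 23400 nM, the only actual number among the compounds tested so far. Compound 1 `COc1ccccc1-c1cc(O)c2ccc(C)nc2n1`, which carries a methyl on the shared core, is recorded at > 100000 nM, and this is a limit of the assay rather than a number. Compound 3 `COc1ccccc1-c1cc(O)c2c(C)ccnc2n1` has not yet been measured. It is compound 2 with methyl in place of hydrogen on an aromatic carbon, on the six-membered aromatic ring with 1 nitrogen, opposite the ring nitrogen: methyl in place of hydrogen on an aromatic carbon.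

Within the data shown here, only one measured step bears on this change. It is an at least 4.2-fold lower number from compound 1 to compound 2 (0.63 log units; beyond the scatter), in which hydrogen replaced methyl on an aromatic carbon. The methyl of compound 3 sits at a different carbon from that of compound 1, so this step offers only indirect guidance, but it does suggest that adding a methyl will move the number upward in this assay. A modest loss of growth inhibition is therefore expected, with the estimated step being a 2.1-fold higher number from compound 2 to compound 3 (0.33 log units; beyond the scatter). The estimate for compound 3 is 50000 nM, with an expected range from 15000 nM to 100000 nM.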

Compound 3, concentration for 50% growth inhibition: 23400 nM
Beside the measured number, compound 3's estimate is 2.1-fold (0.33 log units) above it, within the range that was stated.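

In this assay, methyl in place of hydrogen on an aromatic carbon, opposite the ring nitrogen, gives no change at the digits printed from compound 2 to compound 3 (within the scatter). The earlier step, an at least 4.2-fold lower number from compound 1 to compound 2 (0.63 log units; beyond the scatter), had linked a methyl at another carbon of the shared core to a higher number, and compound 3 goes against any reading of that link as a general effect of adding a methyl. Among these compounds, then, the outcome of the change depends on which carbon carries the methyl, and the carbon opposite the ring nitrogen accepts it with no shift beyond the scatter, though the size of the earlier step stays unknown, as compound 1 is recorded only at a limit and not at a number: the limit of > 100000 nM in this assay, at which 1 of the 3 values shown sits.

Whether a longer chain, an amine or a carboxylic acid at the carbon opposite the ring nitrogen would leave the number equally unmoved remains open, as methyl is the only group shown there. The compounds also leave open why the two methyl positions part ways, as no measured property other than growth inhibition is given for them.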